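Swapping Benzyl for Difluoromethyl on an Aromatic Ether Oxygen

This account rests on a few compounds, and the source may have more. Where it says the series, first, only, none or still open, it means among the compounds named here.

Of the compounds shown here, three with a shared core have been tested in an assay on mitochondria from L6 cells (Rattus norvegicus) for activation, with a stated time of 90 min; on this read-out lower numbers stand for an effect already at smaller amounts and higher numbers for an effect only at larger amounts of compound. Compound 3 `Oc1nc2nonc2nc1Nc1ccc(OCc2ccccc2)cc1` gives 2400 nM. Compound 1 `Oc1nc2nonc2nc1Nc1ccc(OC(F)(F)F)c(Cl)c1` gives 3000 nM, which lies within the scatter of compound 3, whereas compound 2 `Cc1cc(Nc2nc3nonc3nc2O)ccc1OCC(F)(F)F` gives 7000 nM, a number beyond the scatter from compound 3. Compound 4 `Oc1nc2nonc2nc1Nc1ccc(OC(F)F)cc1` has not yet been measured. It differs from compound 3 in one place: difluoromethyl in place of benzyl on an oxygen on an aromatic ring. Going by the values given here, no measured pair isolates this change, so its size is uncertain. Because compound 1 gives 3000 nM while carrying a different group in that same place, the expected step of a 1.5-fold higher number from compound 3 to compound 4 (0.16 log units; within the scatter) is small, toward a higher number, and within the scatter. Compound 4 is estimated at 3500 nM, with a range from 1200 nM to 10000 nM.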

Compound 4, half-maximal effective concentration: 20600 nM
The estimate for compound 4 lay 5.9-fold (0.77 log units) below the measured number; measured number above the stated range.
By their numbers in this assay, from the lowest: compounds 3 and 1 (each within the scatter of the next); then compound 2; then compound 4.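

In this assay, difluoromethyl in place of benzyl on an oxygen on an aromatic ring gives an 8.6-fold higher number from compound 3 to compound 4 (0.93 log units; beyond the scatter), so the group at this place clearly affects the read-out. This single change removes an aromatic ring and reduces the heavy-atom count of the group, and the two cannot be told apart here. Nothing shown explains the step. On these data alone, it remains open whether the ring or the size of benzyl matters more; cyclohexylmethyl or a longer chain on that oxygen would help separate them.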